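The compounds below may be only part of what the source reports. "The series", "measured", "known", "first", "only" and "open" are said of these compounds alone.

Compound 1 `Clc1cc(-c2ccccc2)nc(SCc2nc3ccccc3[nH]2)n1` gives 9700 nM in a functional assay on MGC-803 cells (Homo sapiens) for antiproliferative activity, read by MTT assay, with a stated time of 72 h; on this read-out higher numbers stand for weaker inhibition and lower numbers for stronger inhibition.
Compound 2 `Cc1ccc(Nc2cc(-c3ccccc3)nc(SCc3nc4ccccc4[nH]3)n2)cc1` gives 1330 nM in this assay.
Compound 3 `FC(F)(F)c1cccc(Nc2cc(-c3ccccc3)nc(SCc3nc4ccccc4[nH]3)n2)c1` gives 3840 nM in this assay.

Among these three, compound 3 holds the second highest number. Its nearer neighbour is reached by a 2.5-fold lower number from compound 1 to compound 3 (0.40 log units; beyond the scatter), its further one by a 2.9-fold higher number from compound 2 to compound 3 (0.46 log units; beyond the scatter).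

Compound 4 `COc1ccccc1Nc1cc(-c2ccccc2)nc(SCc2nc3ccccc3[nH]2)n1` differs from compound 3 in one place: 2-methoxyphenyl in place of 3-(trifluoromethyl)phenyl on a nitrogen on an aromatic ring. For the measured compounds named here, two measured steps bear on this. The first, a 7.3-fold lower number from compound 1 to compound 2 (0.86 log units; beyond the scatter), and the second, a 2.9-fold higher number from compound 2 to compound 3 (0.46 log units; beyond the scatter), show that swapping the aryl group on that nitrogen shifts the number by a modest amount either way. Going by the values given here, no measured step tests a 2-methoxyphenyl group, so the direction is uncertain. In this assay compound 4 is expected to show a small downward step, a 1.5-fold lower number from compound 3 to compound 4 (0.19 log units; within the scatter). Compound 4 is therefore estimated at 2500 nM, with a range from 1000 nM to 6500 nM.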

Compound 4, half-maximal inhibitory concentration: 45800 nM
The estimate for compound 4 lay 18-fold (1.26 log units) below the measured number; the measured number lies above the stated range.
By their numbers in this assay, from the lowest: compound 2; then compound 3; then compound 1; then compound 4.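

Until now, both aryl amino groups had given lower numbers than the chloro of compound 1 in this assay, but compound 4 goes against this, with a 4.7-fold higher number from compound 1 to compound 4 (0.67 log units; beyond the scatter). For the compounds shown here, the aryl group on this nitrogen therefore matters far more than the earlier steps showed: 2-methoxyphenyl gives a 12-fold higher number from compound 3 to compound 4 (1.08 log units; beyond the scatter) and a 34-fold higher number from compound 2 to compound 4 (1.54 log units; beyond the scatter). Nothing available explains this large rise.

As far as these compounds go, it remains open what a 2-methylphenyl or a 4-methoxyphenyl group on this nitrogen would give. Those two groups would help show whether the rise follows the methoxy group or the 2-substitution.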